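Volume of distribution notes: from compound 2 to compound 4

The source may hold more compounds than are shown below. What is called first, only, known or untested is meant among the compounds shown, and "the series" means these compounds.

Of the compounds shown here, three have so far been measured in an ADME assay (Rattus norvegicus, strain Wistar Han) for pharmacokinetics; on this read-out lower numbers stand for narrower distribution and higher numbers for wider distribution into tissues. Compound 1 `CCn1c(-c2cnc(C)nc2)nc2c(O[C@H]3CCN(C(=O)C4CC4)C3)ncnc21` gives 2.8 L/kg, compound 3 `CCn1c(-c2ccc(C(F)(F)F)nc2)nc2c(O[C@H]3CCN(C(=O)N4CC(OC)C4)C3)ncnc21` gives 4.2 L/kg, and compound 2 `CCn1c(-c2cnc(C)nc2)nc2c(N[C@H]3CCN(C(=O)C4CCC4)C3)ncnc21` gives 9.2 L/kg. Compound 2 thus stands highest of the three in this assay, with compound 3 the nearer of the other two and compound 1 the furthest away; both gaps lie beyond the scatter. Compound 4 `CCn1c(-c2cnc(C)nc2)nc2c(N[C@H]3CCN(C(=O)C4CC4)C3)ncnc21` has not yet been measured. It differs from compound 2 in one place: cyclopropyl in place of cyclobutyl on a carbonyl carbon. Among the measured compounds shown here, no measured pair isolates this change, so only a small step is expected, downward if anything and likely within the scatter: a 1.3-fold lower number from compound 2 to compound 4 (0.12 log units; within the scatter). In this assay compound 4 is therefore estimated at about 7 L/kg, within a range from 3.5 L/kg to 14 L/kg.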

Compound 4, volume of distribution: 6.3 L/kg
Compound 4: the middle estimate sits 1.1-fold (0.05 log units) above what was measured; low and high end bracket the measured number.
By their numbers in this assay, from the lowest: compounds 1, 3, 4 and 2 (each within the scatter of the next, the first and the last beyond it).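

In this assay, among the compounds shown here, the pair gives the first direct reading at this position: a 1.5-fold lower number from compound 2 to compound 4 (0.16 log units; within the scatter), so exchanging cyclobutyl for cyclopropyl on this carbonyl carbon produces no change that can be separated from the scatter. The read-out therefore tolerates this one-carbon difference in ring size, at least with the rest of compound 2 held constant. No measured evidence is available to explain the result.

The compounds shown leave open whether a longer alkyl chain or an amine on the same carbonyl carbon would also leave the read-out within the scatter. Whether the same exchange behaves alike on a different core also remains unresolved.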